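The source may report more compounds than this note shows. Statements on the series, on what has been measured and on what is new or still open speak of the compounds shown alone.

Three compounds built on the shared core of compound 1 `Cc1cc(=O)oc2cc(SCc3ccccn3)ccc12` have been tested in a functional assay on A549 cells (Homo sapiens) for antiproliferative activity, read by sulforhodamine B assay, with a stated time of 72 h; on this read-out lower numbers stand for stronger inhibition of growth and higher numbers for weaker inhibition of growth. In this assay compound 1 reaches only a limit of the assay, > 35200 nM. Compound 2 `Cc1cc(=O)oc2cc(SCc3cccnc3)ccc12` likewise stops at a limit, > 35200 nM. The step that the two limits leave unreadable from compound 1 to compound 2 is therefore not readable. Compound 3 `Cc1cc(=O)oc2cc(SCc3cccc(C#N)c3)ccc12` also stands at a limit, > 32500 nM. So all three results are limits: the limit of > 32500 nM in this assay, at which 1 of the 3 values shown sits, and (the limit of > 35200 nM in this assay, at which 2 of the 3 values shown sit). Compound 3 thus stands where the others stand, with no number to separate it from them.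

Compound 4 `Cc1cccc(CSc2ccc3c(C)cc(=O)oc3c2)c1` differs from compound 3 by methyl in place of cyano on an aromatic carbon. Within the data shown here, no measured step touches this exchange; the single measured step, from compound 1 to compound 2, could not be read at all, and the three compounds give no clue how a methyl compares with a cyano. With nothing pointing to a gain, compound 4 is expected to stay near the limit, estimated at 40000 nM, between 12000 nM and 120000 nM. The expected step that the limit leaves unreadable from compound 3 to compound 4 is thus estimated to be none beyond the scatter.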

Compound 4, concentration for 50% growth inhibition: > 33700 nM
Compound 4: only a limit was reported (the forecaster's own chance of this, stated with the estimate: 75%); the middle value does not contradict the limit.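

Compound 4, like compound 1, compound 2 and compound 3, gives only a limit, so none of the steps joining these four compounds can be read. The compounds shown leave open whether exchanging these groups changes growth inhibition at all in this assay.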